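Sulfonyl aryl exchange: compound 2 to compound 3

The source may hold more compounds than are shown below. What is called first, only, known or untested is meant among the compounds shown, and "the series" means these compounds.

Measured so far:
compound 1 `CC1CCN(c2c(S(=O)(=O)c3ccccc3)cnc3cc(Cl)ccc23)CC1`: 93%
compound 2 `CC1CCN(c2c(S(=O)(=O)c3ccc(Cl)c(Cl)c3)cnc3cc(Cl)ccc23)CC1`: 89%

In an assay on isolated protein for displacement of a labelled ligand from metabotropic glutamate receptor 5 (Homo sapiens), with a stated time of 60 min, tested at 1 uM (on this read-out higher numbers stand for more inhibition at the one concentration tested (going by the name of the read-out) and lower numbers for less inhibition), compound 1 gives 93%, while compound 2 gives 89%. Going by the values given here, the only measured step, a number 4 percentage points lower from compound 1 to compound 2 (within the scatter), changes the group on the sulfonyl sulfur and leaves the read-out essentially unmoved; compound 2 therefore stands alongside compound 1, the two numbers not separated beyond the scatter.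

Compound 3 `COc1ccc(S(=O)(=O)c2cnc3cc(Cl)ccc3c2N2CCC(C)CC2)cc1` carries the change (4-methoxyphenyl in place of 3,4-dichlorophenyl on a sulfonyl sulfur). Among the compounds with values here, it touches the same position as the one measured step, which was within the scatter, so the expectation is again no step beyond the scatter in this assay, in either direction; the single step gives no basis for a larger movement.

Compound 3 is therefore estimated at 88%, range 74% to 97%. The expected step is a number 1 percentage points lower from compound 2 to compound 3 (within the scatter).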

Compound 3, a percentage reported as inhibition, at one concentration (the size of the read-out at that concentration, not a potency): 79%
For compound 3 the middle estimate is 9 percentage points above the measured one; the measured number falls inside the stated range.
By their numbers in this assay, from the lowest: compounds 3, 2 and 1 (each within the scatter of the next, the first and the last beyond it).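

In this assay, the group on the sulfonyl sulfur now shows a first movement beyond the scatter: methoxy in place of hydrogen on an aromatic carbon gives a number 14 percentage points lower from compound 1 to compound 3 (beyond the scatter), a modest step. Going by these compounds alone, the exchange of 3,4-dichlorophenyl for 4-methoxyphenyl gives a number 10 percentage points lower from compound 2 to compound 3 (within the scatter), so this place is not fully indifferent to its aryl group, although only the step from compound 1 clears the scatter. Nothing measured here accounts for the lower number with methoxy.

The compounds shown leave open whether an amine or a carboxylic acid in place of the methoxy would stay level with compound 1 or fall further. Also open, from the compounds shown here alone, is whether the methoxy step keeps its size when other parts of the shared core change.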